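The compounds below may be only part of what the source reports. "The series", "measured", "known", "first", "only" and "open" are said of these compounds alone.

Compound 1 `CC1(C)O[C@H]2C=C[C@@H](OC(=O)c3ccccc3)[C@H](O)[C@@]2(COC(=O)c2ccccc2)O1` gives > 50000 nM in a functional assay on KB cells (Homo sapiens) for cytotoxicity (a lower number here means a stronger inhibitor, a higher number a weaker inhibitor), which is a limit of the assay rather than a number.
Compound 2 `O=C(OC[C@]1(O)[C@@H](O)C=C[C@@H](O)[C@@H]1O)c1ccccc1` gives > 50000 nM in this assay, again only a limit.
Compound 3 `CC(=O)O[C@H]1C=C[C@@H](Cl)[C@@](O)(COC(=O)c2ccccc2)[C@@H]1O` gives > 50000 nM in this assay, once more a limit.

All three measured compounds therefore sit at the limit of > 50000 nM in this assay, at which 3 of the 3 values shown sit. None of them yields a measurable number, and compound 3 stands exactly where the other two stand: at the limit of the assay, with no value that would set it apart. For the measured compounds named here, no pair of the measured compounds differs in only one place, and no step between them is drawn.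

Compound 4 `O=C(OC[C@]1(O)[C@H](Cl)C=C[C@H](O)[C@H]1O)c1ccccc1` differs from compound 3 by hydrogen in place of acetyl on an oxygen on a saturated carbon. Read one bond further out, the same change is acetoxy to hydroxy, on an oxygen on a saturated carbon whose other neighbour is a saturated ring carbon.

With every measured compound at the limit, nothing in the numbers points toward a stronger inhibitor. The step from compound 3 to compound 4 in this assay is expected to be none beyond the scatter, a step that the limit leaves unreadable from compound 3 to compound 4. Compound 4 is estimated at 100000 nM, with a range from 30000 nM to 500000 nM, and the assay is expected most likely to report only a limit for it again.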

Compound 4, half-maximal inhibitory concentration: > 50000 nM
Compound 4: only a limit was reported; the forecaster's own chance of this, stated with the estimate: 85%; the middle value does not contradict the limit.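

In this assay compound 3 and compound 4 each give only a limit, so no step can be read for the change from acetoxy to hydroxy. All the compounds shown stand at the same place: the limit of > 50000 nM in this assay, at which 4 of the 4 values shown sit. On these data alone, what stays open is whether any change to the shared core would give a measurable number in this assay at all.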